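From 3-chlorophenyl to pyridin-3-yl on a shared amide core

The source may report more compounds than this note shows. Statements on the series, on what has been measured and on what is new or still open speak of the compounds shown alone.

Three compounds sharing one core have been measured in a functional assay (Sus scrofa) with sulfonylurea receptors; K-ATP channels (Homo sapiens) as the target; on this read-out lower numbers stand for smaller maximal responses and higher numbers for larger maximal responses:

Compound 1, `CCCC(=O)Nc1c(C(O)(C(F)(F)F)C(F)(F)F)ccc2ccccc12`: 92%
Compound 2, `O=C(Nc1c(C(O)(C(F)(F)F)C(F)(F)F)ccc2ccccc12)C1CCC1`: 97%
Compound 3, `O=C(Nc1c(C(O)(C(F)(F)F)C(F)(F)F)ccc2ccccc12)c1cccc(Cl)c1`: 84%

The three differ only in the group on the carbonyl carbon of the amide. Compound 3 carries the 3-chlorophenyl and gives the lowest of the three numbers. Its nearest neighbour is compound 1, whose value is within the usual scatter, as a number 8 percentage points lower from compound 1 to compound 3 (within the scatter) shows. Compound 2 lies furthest away, and a number 13 percentage points lower from compound 2 to compound 3 (beyond the scatter) is a modest step beyond the scatter. Between compound 1 and compound 2, a number 5 percentage points higher from compound 1 to compound 2 (within the scatter) stays inside the scatter.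

Compound 4, `O=C(Nc1c(C(O)(C(F)(F)F)C(F)(F)F)ccc2ccccc12)c1cccnc1`, has not yet been measured. It differs from compound 3 in one place: pyridin-3-yl in place of 3-chlorophenyl on a carbonyl carbon. Within the data shown here, both of the measured steps that lead to compound 3 concern the arrival of the 3-chlorophenyl, and neither of them involves a pyridin-3-yl, so no measured step bears directly on this change. The two steps that do touch compound 3 were small, one within the scatter and one modestly beyond it, which suggests that exchanging one six-membered aromatic ring for another will also move the read-out little.

For compound 4 the estimate in this assay is therefore 86%, with a range from 72% to 98%. Against compound 3 this estimate means a step of a number 2 percentage points higher from compound 3 to compound 4 (within the scatter), expected to stay within the scatter.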

Compound 4, largest response reached (reported as efficacy), in percent of the reference or control that the assay uses: 97%
The estimate for compound 4 lay 11 percentage points below the measured number, within the range that was stated.
By their numbers in this assay, from the lowest: compounds 3, 1, 2 and 4 (each within the scatter of the next, the first and the last beyond it).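

In this assay, exchanging the 3-chlorophenyl for pyridin-3-yl gives a number 13 percentage points higher from compound 3 to compound 4 (beyond the scatter) and shows that a six-membered aromatic ring on this carbonyl carbon does not by itself go with the value of compound 3. The other two comparisons support this, with no change at the digits printed from compound 2 to compound 4 (within the scatter) and a number 5 percentage points higher from compound 1 to compound 4 (within the scatter), so this aromatic ring with one hetero atom sits within the scatter of both the cyclobutyl and propyl groups. No measurement shown here accounts for the step between the two aromatic rings.

This exchange removes the chlorine and brings a ring nitrogen in a single change, so the compounds shown cannot assign the step to either one, and a plain phenyl group at this place would separate the two. Pyridin-2-yl and pyridin-4-yl groups would add to this by showing whether the read-out stays the same when the ring nitrogen sits elsewhere in the ring.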